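A Methyl on the Oxadiazole of Compound 2

The source may hold more compounds than are shown below. What is called first, only, known or untested is meant among the compounds shown, and "the series" means these compounds.

Compound 2 `CCCN(CCC)C[C@@H](C)NC(=O)c1ccc(-c2ncon2)cc1` gives no measurable inhibition in an assay on isolated protein for inhibition of histone deacetylase 4 (Homo sapiens), read by fluorescence; on this read-out lower numbers stand for stronger inhibition and higher numbers for weaker inhibition: its reading of > 50000 nM is a limit of the assay, not a number (the limit of > 50000 nM in this assay, at which 1 of the 3 values shown sits). Compound 1 `C[C@H](CN1CCCC(C)(C)C1)NC(=O)c1ccc(-c2noc(C(F)(F)F)n2)cc1` gives 2 nM, and compound 3 `CC(C)(CN1CCCC1)NC(=O)c1ccc(-c2noc(C(F)(F)F)n2)cc1` gives 280 nM; both carry a trifluoromethyl on the five-membered ring, which compound 2 lacks, and both carry a different amine. Compound 4 `CCCN(CCC)C[C@@H](C)NC(=O)c1ccc(-c2noc(C)n2)cc1` differs from compound 2 by methyl in place of hydrogen on an aromatic carbon. For the measured compounds named here, no measured pair shows this change alone, and compound 2 offers only a limit, so the expected step is a modest gain at most, estimated as an at least 2.5-fold lower number from compound 2 to compound 4 (0.39 log units; beyond the scatter). Compound 4 is therefore estimated at 20000 nM, within 3000 nM to 100000 nM, with a real chance that only a limit is returned again.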

Compound 4, half-maximal inhibitory concentration: > 50000 nM
Compound 4 gave a limit, no number; the forecaster's own chance of this, stated with the estimate: 50%; middle value at least 2.5-fold (0.39 log units) away from the limit.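

Compound 2 and compound 4 both return only a limit in this assay, so no step can be read between them: the limit of > 50000 nM in this assay, at which 2 of the 4 values shown sit.

From the compounds shown here alone, whether methyl in place of hydrogen on this ring changes inhibition at all remains open.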